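Acetyl for Methyl on a Macrocyclic Ring Amine

The source may report more compounds than this note shows. Statements on the series, on what has been measured and on what is new or still open speak of the compounds shown alone.

Of the compounds shown here, three sharing a fused four-ring core have been tested in a functional assay on HCT-116 cells (Homo sapiens) for antiproliferative activity; a higher number here means a weaker inhibitor, a lower number a stronger inhibitor. Compound 1 `Cc1c2c(n3c1CCCN(C)[C@@H](C)[C@H](C)Nc1cc-3ccc1C(N)=O)CC(C)(C)CC2=O` gives 51 nM. Compound 3 `CC(=O)N1CCCc2c(C)c3c(n2-c2ccc(C(N)=O)c(c2)N[C@@H](C)[C@@H]1C)CC(C)(C)CC3=O` differs from it by acetyl in place of methyl on an amine nitrogen in a ring, and gives 27 nM, a step of a 1.9-fold lower number from compound 1 to compound 3 (0.28 log units; within the scatter). Compound 2 `Cc1c2c(n3c1CCN(C)C[C@@H](C)[C@H](C)Nc1cc-3ccc1C(N)=O)CC(C)(C)CC2=O` has the same atoms as compound 1 joined differently; the difference between the two cores is not broken down here. In this assay compound 2 gives 27 nM. Compound 4 `CC(=O)N1CCc2c(C)c3c(n2-c2ccc(C(N)=O)c(c2)N[C@@H](C)[C@H](C)C1)CC(C)(C)CC3=O` carries acetyl in place of methyl on an amine nitrogen in a ring relative to compound 2, the same kind of change as from compound 1 to compound 3, though the surroundings differ: in compound 3 the nitrogen sits next to the ring atom that bears a methyl group, three and five ring bonds from the ring nitrogen, whereas in compound 4 it sits two and three ring bonds from the ring atoms bearing methyl groups and four ring bonds from the ring nitrogen. The expected step is a 1.4-fold lower number from compound 2 to compound 4 (0.13 log units; within the scatter), resting on the measured step of a 1.9-fold lower number from compound 1 to compound 3 (0.28 log units; within the scatter). Compound 4 is therefore estimated at 20 nM, between 8 nM and 50 nM.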

Compound 4, half-maximal inhibitory concentration: 24 nM
Beside the measured number, compound 4's estimate is 1.2-fold (0.08 log units) below it; low and high end bracket the measured number.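

In this assay, acetyl in place of methyl on the amine nitrogen in the ring gives a 1.1-fold lower number from compound 2 to compound 4 (0.05 log units; within the scatter), so on this second core the change again stays within the scatter. Set beside the earlier step, the two cores show no difference that can be told apart in how the change carries over: the same change on two cores in this assay, a 1.9-fold lower number (0.28 log units; within the scatter) from compound 1 to compound 3 and a 1.1-fold lower number (0.05 log units; within the scatter) from compound 2 to compound 4, 1.7-fold (0.23 log units) apart, within the scatter of two such steps. This shows that the swap is tolerated on both cores in this one assay, but with both steps inside the scatter it does not show that acetyl gives a real gain on either core, and two pairs set no rule for the series.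

The compounds shown leave open what other groups on that nitrogen would do, such as a longer acyl chain or a sulfonamide. They also leave open whether the same picture would hold on the nitrogen left free of any group.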